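Sulfonate to sulfonamide on a chloropropylurea scaffold

A few compounds are considered here, and "the series" means these few. Any claim that something is new, unique, unknown or untested is made for them only; others in the source may bear on it.

The measured compounds are:
compound 1, `Cc1ccccc1OS(=O)(=O)c1cccc(NC(=O)NCCCCl)c1`, with 27000 nM;
compound 2, `CCc1ccccc1OS(=O)(=O)c1cccc(NC(=O)NCCCCl)c1`, with 25000 nM;
compound 3, `O=C(NCCCCl)Nc1cccc(S(=O)(=O)Oc2ccc(O)cc2)c1`, with 51000 nM.

All three were tested in a functional assay on MCF7 cells (Homo sapiens) for cytotoxicity, read by sulforhodamine B assay, with a stated time of 48 h; on this read-out higher numbers stand for weaker inhibition and lower numbers for stronger inhibition. Compound 3 has the highest number of the three: its difference to compound 2 is beyond the scatter, as a 2.0-fold higher number from compound 2 to compound 3 (0.31 log units; beyond the scatter) shows, whereas its difference to compound 1 stays within the scatter, as a 1.9-fold higher number from compound 1 to compound 3 (0.28 log units; within the scatter) shows. Compound 1 and compound 2 are within the scatter of each other, as a 1.1-fold lower number from compound 1 to compound 2 (0.03 log units; within the scatter) shows.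

Compound 4, `Cc1ccccc1NS(=O)(=O)c1cccc(NC(=O)NCCCCl)c1`, has not yet been measured. It differs from compound 3 in one place: (2-methylphenyl)amino in place of 4-hydroxyphenoxy on a sulfonyl sulfur. Among the measured compounds shown here, the only measured step that bears on this change is the one between compound 1 and compound 3, which swaps the same two aryl groups but on an oxygen, and which lay within the scatter. For the measured compounds named here, no measured step covers the exchange of the oxygen link for a nitrogen link on the sulfonyl sulfur, so that part is unknown. On this basis compound 4 is expected to land near compound 1, with a step of a 1.9-fold lower number from compound 3 to compound 4 (0.28 log units; within the scatter) that is expected to be small. The estimate for compound 4 is 27000 nM, with a range from 8000 nM to 90000 nM.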

Compound 4, half-maximal inhibitory concentration: 52000 nM
Estimate against measurement, compound 4: 1.9-fold (0.28 log units) below, and the stated range covers the measured number.
By their numbers in this assay, from the lowest: compounds 2, 1, 3 and 4 (each within the scatter of the next, the first and the last beyond it).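

At the sulfonyl sulfur, (2-methylphenyl)amino in place of 4-hydroxyphenoxy changes both the linking atom and the aryl group, yet in this assay this double exchange gives a 1.0-fold higher number from compound 3 to compound 4 (0.01 log units; within the scatter) and so does not move the number beyond the usual scatter. Among the compounds shown here, the step that keeps the 2-methylphenyl group and alters only the link, with (2-methylphenyl)amino in place of 2-methylphenoxy, gives a 1.9-fold higher number from compound 1 to compound 4 (0.28 log units; within the scatter) and also stays within the scatter, so these compounds offer the first reading of a nitrogen link on this sulfur and show no difference from the oxygen link that can be told from repeated measurement. No measured evidence is available to explain these numbers.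

Going by these compounds, it remains open whether the same holds for other aryl groups on the nitrogen link, such as 2-ethylphenyl or 4-hydroxyphenyl, or for a methyl group on the sulfonamide nitrogen itself. Also open, on these data alone, is how the numbers would respond to an amine or a carboxylic acid on that aryl ring, or to a longer chain in place of the chloropropyl chain on the urea.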